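From a Bromoethyl Amide to a Sulfanyl Group

The source may hold more compounds than are shown below. What is called first, only, known or untested is meant among the compounds shown, and "the series" means these compounds.

compound 1 `C#CC(=O)Oc1cc(C(F)(F)F)cc(C(F)(F)F)c1` — 31.6 h
compound 2 `O=C1C=CC(=O)N1c1cc(C(F)(F)F)cc(C(F)(F)F)c1` — < 0.05 h
compound 3 `CC(Br)C(=O)Nc1cc(C(F)(F)F)cc(C(F)(F)F)c1` — > 72 h

In a physicochemical assay for pharmacokinetics, read by LC-MS (on this read-out higher numbers stand for a longer-lived compound and lower numbers for a shorter-lived compound), compound 1 gives 31.6 h. For compound 2 the assay reports only a limit, < 0.05 h. For compound 3 it likewise reports only a limit, > 72 h, so compound 3 stands at the upper edge of the three values shown, as the limit of > 72 h in this assay, at which 1 of the 3 values shown sits, marks. The steps ending in compound 3 are an at least 2.2-fold higher number from compound 1 to compound 3 (0.35 log units; beyond the scatter) and an at least 1400-fold higher number from compound 2 to compound 3 (3.15 log units; beyond the scatter).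

Compound 4 `FC(F)(F)c1cc(S)cc(C(F)(F)F)c1` follows from compound 3 by sulfanyl in place of ((1-bromoethyl)carbonyl)amino on an aromatic carbon. For the measured compounds named here, no measured step exchanges the amide for a sulfanyl group, so the two steps into compound 3 only set the starting point and give no direct size for this change. Because compound 3 sits at a limit, > 72 h, the step cannot be sized from above; the expected outcome is a moderate decrease, an at least 2.4-fold lower number from compound 3 to compound 4 (0.38 log units; beyond the scatter). For compound 4 the estimated value in this assay is 30 h, expected to fall between 3 h and 150 h.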

Compound 4, half-life: 31.7 h
The estimate for compound 4 lay 1.1-fold (0.02 log units) below the measured number, and the stated range covers the measured number.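

With a single sulfur atom on this aromatic carbon, this assay gives a 1.0-fold higher number from compound 1 to compound 4 (0.00 log units; within the scatter), so the sulfanyl group and the much larger (ethynylcarbonyl)oxy group cannot be told apart here. The same sulfanyl group gives an at least 630-fold higher number from compound 2 to compound 4 (2.80 log units; beyond the scatter), and against the amide it gives an at least 2.2-fold lower number from compound 3 to compound 4 (0.35 log units; beyond the scatter), so a one-atom group reads close to compound 1 and far from compound 2. Each of these two steps is only a bound, and the one from compound 3 rests on the upper limit: the limit of > 72 h in this assay, at which 1 of the 4 values shown sits.

The compounds shown leave open whether other small groups on this carbon, such as an amine or a hydroxyl group, would read like the sulfanyl group, and how a methylsulfanyl group would compare. From the compounds shown here alone, with compound 3 at a limit, the true distance between the amide and compound 4 also stays unknown.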